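Swapping the Nitrogen Substituent for a Tosyl Group

This account rests on a few compounds, and the source may have more. Where it says the series, first, only, none or still open, it means among the compounds named here.

Compound 1 `COc1ccc(-c2cc(=O)c3c(OC)cc(OC)cc3[nH]2)cc1` carries a hydrogen on the aromatic nitrogen of its core. In a functional assay on KOPN-8 cells (Homo sapiens) for antiproliferative activity, with a stated time of 72 h (a higher number here means that more compound is needed for the effect, a lower number that less compound is needed), compound 1 reaches only the limit of the assay, > 31100 nM. Compound 2 `C=CCNC(=O)n1c(-c2ccc(OC)cc2)cc(=O)c2c(OC)cc(OC)cc21` has an allylcarbamoyl group on that nitrogen instead. In this assay, for the measured compounds named here, compound 2 gives 12000 nM; this is the only actual number among the values shown. The step of an at least 2.5-fold lower number from compound 1 to compound 2 (0.41 log units; beyond the scatter) indicates that occupying this nitrogen is at least modestly favourable. Compound 3 `COc1ccc(-c2cc(=O)c3c(OC)cc(OC)cc3n2S(=O)(=O)c2ccc(C)cc2)cc1` changes the same position again: (4-methylphenyl)sulfonyl in place of allylcarbamoyl on an aromatic nitrogen. Going by the values given here, only the step from compound 1 to compound 2 bears on this change, and it was at least modest. Since both compound 2 and compound 3 are substituted at the nitrogen, the account expects a step of a 1.5-fold lower number from compound 2 to compound 3 (0.18 log units; within the scatter) within or near the scatter. Compound 3 is therefore estimated at 8000 nM, within 2500 nM to 25000 nM.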

Compound 3, half-maximal effective concentration: > 44800 nM
Compound 3: no number, only a limit (the forecaster's own chance of this, stated with the estimate: 20%); middle value at least 5.6-fold (0.74 log units) away from the limit.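

In this assay compound 3 gives only a limit, > 44800 nM. Putting (4-methylphenyl)sulfonyl in place of allylcarbamoyl gives an at least 3.7-fold higher number from compound 2 to compound 3 (0.57 log units; beyond the scatter), so occupying this aromatic nitrogen does not by itself lower the number, and among the groups shown the outcome depends on which group enters. The comparison of compound 1 with compound 3 cannot be read, as both values are limits.

The compounds shown leave open which part of allylcarbamoyl goes with the lower number, since the two groups differ in more than one feature. As far as these compounds go, it also remains open how a smaller group such as methyl or acetyl, or a longer chain on the carbamoyl nitrogen such as butylcarbamoyl, would behave at this position.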